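The source may report more compounds than this note shows. Statements on the series, on what has been measured and on what is new or still open speak of the compounds shown alone.

Series notes. Compound 1 `c1ccc(COc2ccccc2Nc2ncnc3cc4c(cc23)OCCOCCO4)cc1` is the unsubstituted benzyloxy member; in a functional assay on A549 cells (Homo sapiens) for antiproliferative activity, read by MTT assay, with a stated time of 72 h (on this read-out higher numbers stand for weaker inhibition and lower numbers for stronger inhibition), compound 1 returns only the limit > 100000 nM. Compound 2 `FC(F)(F)c1ccc(COc2ccccc2Nc2ncnc3cc4c(cc23)OCCOCCO4)cc1` carries trifluoromethyl in place of hydrogen on an aromatic carbon; in this assay compound 2 likewise returns only the limit > 100000 nM. Compound 3 `FC(F)(F)c1ccc(COc2ccc(Nc3ncnc4cc5c(cc34)OCCOCCO5)cc2)cc1` is a further trifluoromethyl member; in this assay compound 3 also returns only the limit > 100000 nM. The single-change step that the two limits leave unreadable from compound 1 to compound 2 cannot be sized because both of its ends sit at the limit of > 100000 nM in this assay, at which 3 of the 3 values shown sit. Compound 2 therefore stands at the limit, with no number separating it from compound 1 or compound 3.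

Compound 4 `O=[N+]([O-])c1ccc(COc2ccccc2Nc2ncnc3cc4c(cc23)OCCOCCO4)cc1` differs from compound 2 by nitro in place of trifluoromethyl on an aromatic carbon. For the measured compounds named here, no measured step bears directly on this exchange, and the one step with a single change, from compound 1 to compound 2, is unreadable. Every value shown is a limit, so the expected step that the limit leaves unreadable from compound 2 to compound 4 in this assay is none beyond the scatter. For compound 4 the estimate in this assay is 150000 nM, ranging from 40000 nM to 500000 nM, most likely reported again as a limit.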

Compound 4, half-maximal inhibitory concentration: 28400 nM
Estimate against measurement, compound 4: 5.3-fold (0.72 log units) above; the whole stated range lies above it.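

For the compounds shown here, with compound 4, the exchange on the benzyl ring in this assay gives the series readable steps for the first time: trifluoromethyl to nitro gives an at least 3.5-fold lower number from compound 2 to compound 4 (0.54 log units; beyond the scatter). Against the unsubstituted member, the same position gives an at least 3.5-fold lower number from compound 1 to compound 4 (0.54 log units; beyond the scatter), so a group at this place can move the read-out, which trifluoromethyl in compound 2 did not show. Both steps are minimum sizes, since their starting ends are limits and not numbers: the limit of > 100000 nM in this assay, at which 3 of the 4 values shown sit.

On these data alone, the full size of either step stays open, as does whether the drop belongs to nitro alone or would also appear with a nitrile, an amine or a carboxylic acid at this position. Whether nitro would act alike in the arrangement of compound 3 also remains unsettled.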